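Swapping a hydroxy for a carbamoylmethyl side chain

The source may report more compounds than this note shows. Statements on the series, on what has been measured and on what is new or still open speak of the compounds shown alone.

Measured compounds:
- Compound 1, `O=C(O)[C@@H]1CCCN1C(=O)CN(c1nc(Cl)nc2[nH]cnc12)C1CC1`, gives 26% in a functional assay on the whole organism (Tail, strain ICR) with Mus musculus as the target, in the tail flick test, with a stated time of 90 min, at a dose of 25 umol/kg by the oral route; on this read-out lower numbers stand for a weaker effect and higher numbers for a stronger effect at the one dose given.
- Compound 2, `N=C(N)NCCC[C@H](NC(=O)CN(c1ncnc2c1ncn2C1CCCCO1)C1CC1)C(=O)OCc1ccccc1`, gives 61.6%.
- Compound 3, `O=C(CN(c1ncnc2c1ncn2C1CCCCO1)C1CC1)N[C@@H](CO)C(=O)OCc1ccccc1`, gives 32.2%.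

Among these three, compound 3 stands second highest. Its nearest neighbour is compound 1, whose value lies within the usual scatter of it, so the two cannot be told apart. Within the data shown here, compound 2 stands clearly higher; the single step of a number 29.4 percentage points lower from compound 2 to compound 3 (beyond the scatter) is beyond the scatter.

Compound 4, `NC(=O)CC[C@H](NC(=O)CN(c1ncnc2c1ncn2C1CCCCO1)C1CC1)C(=O)OCc1ccccc1`, has not yet been measured. It differs from compound 3 at one place: carbamoylmethyl in place of hydroxy on a saturated chain carbon, two bonds along the chain from an amide-type nitrogen and a carbonyl carbon.

Among the measured compounds shown here, only one measured step bears on this place, the one between compound 2 and compound 3. There, a group of six heavy atoms on that chain carbon gave a considerably higher number than the hydroxy. Compound 4 again puts a larger group at the same place, though a different one, so a rise relative to compound 3 is plausible, while the size is uncertain because only a number 29.4 percentage points lower from compound 2 to compound 3 (beyond the scatter) is available as a guide. A modest increase is therefore expected, a number 9.8 percentage points higher from compound 3 to compound 4 (within the scatter). For compound 4 the estimated value is 42%, with a likely range from 25% to 60%.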

Compound 4, a percentage reported as activity, at one dose (the size of the read-out at that dose, not a potency): 37.8%
Beside the measured number, compound 4's estimate is 4.2 percentage points above it; the range from low to high includes it.
By their numbers in this assay, from the lowest: compounds 1, 3 and 4 (each within the scatter of the next, the first and the last beyond it); then compound 2.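

In this assay, replacing hydroxy with carbamoylmethyl on this saturated chain carbon gives a number 5.6 percentage points higher from compound 3 to compound 4 (within the scatter), so adding heavy atoms at this place does not by itself separate compound 4 from compound 3. The other new comparison gives a number 23.8 percentage points lower from compound 2 to compound 4 (beyond the scatter): with the chain end changed, the clear difference reappears, so among these compounds the high number belongs to the specific side chain of compound 2, not to just any group larger than hydroxy. No measurement shown here explains why these side chains differ in this way.

The compounds shown leave open whether a simple amine or a carboxylic acid at the end of the same chain would give a number closer to that of compound 2 or to that of compound 4. As far as these compounds go, it also remains open whether a longer chain ending in the carbamoyl group would change the result, and a single dose cannot show whether any of these differences would hold at other doses.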